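The source may report more compounds than this note shows. Statements on the series, on what has been measured and on what is new or still open speak of the compounds shown alone.

The measured compounds and their values:

- compound 1, `CCC(C(=O)N1CCN(c2ccccc2Cl)CC1)N1C(=O)CCC1=O`: 25%
- compound 2, `CCC(C(=O)N1CCN(c2ccc(C(F)(F)F)cc2)CC1)N1C(=O)CCC1=O`: 0%

In a functional assay on the whole organism (strain Swiss) with Mus musculus as the target, in the maximal electroshock model, with a stated time of 0.5 h, at a dose of 300 mg/kg by the intraperitoneal route (on this read-out lower numbers stand for a weaker effect and higher numbers for a stronger effect at the one dose given), compound 1 gives 25%. In this assay compound 2 gives 0%. Compound 2 thus stands at the lowest of the two numbers, and the gap to compound 1 lies beyond the usual scatter of this read-out. Of this pair nothing more can be said than what its two values show.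

The unmeasured compound 3, `CCC(C(=O)N1CCN(c2ccc(F)cc2)CC1)N1C(=O)CCC1=O`, differs from compound 2 in one place: fluoro in place of trifluoromethyl on an aromatic carbon. Among the measured compounds shown here, since no step between measured compounds shows what such a change does on this read-out, any expectation rests on the two values alone. Compound 2 with trifluoromethyl gives 0%, the lowest number this read-out can report, so the value of compound 3 can only be equal or higher. The step of a number 15 percentage points higher from compound 2 to compound 3 (beyond the scatter) is expected to be small, upward, and close to the edge of the scatter. Compound 3 is estimated at 15% in this assay, within a range from 0% to 40%.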

Compound 3, a percentage reported as activity, at one dose (the size of the read-out at that dose, not a potency): 25%
Beside the measured number, compound 3's estimate is 10 percentage points below it; the range from low to high includes it.
By their numbers in this assay, from the lowest: compound 2; then compounds 1 and 3 (each within the scatter of the next).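

Among the compounds shown here, this is the first step read at this position: in this assay fluoro in place of trifluoromethyl on an aromatic carbon gives a number 25 percentage points higher from compound 2 to compound 3 (beyond the scatter) and so shows that the read-out responds to the group at this place. The second step, 4-fluorophenyl in place of 2-chlorophenyl on an amine nitrogen in a ring, gives no change at the digits printed from compound 1 to compound 3 (within the scatter) and so does not separate these two aryl groups in this assay. Nothing at hand gives a reason for either step.

The compounds shown leave open whether a methoxy group, a nitrile or an amine on this aromatic carbon, para to a large group, would read like fluoro or like trifluoromethyl. They also leave open whether chloro at this same place would match fluoro.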